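A few compounds are considered here, and "the series" means these few. Any claim that something is new, unique, unknown or untested is made for them only; others in the source may bear on it.

Within the data shown here, compound 3 `O=C(NCc1ccc(CNS(=O)(=O)c2ccccc2)cc1)c1ccccc1` stands highest of the two numbers so far in a functional assay on the whole organism for inhibition, with Mus musculus as the target, with stated times of 30 min and 2 h, at a dose of 10 mg/kg by the intraperitoneal route (a lower number here means less inhibition, a higher number more inhibition at the dose given (going by the name of the read-out)), where compound 3 gives 62%; compound 1 `O=C(NCc1ccc(CNS(=O)(=O)c2ccccc2)cc1)c1cccnc1` gives 53%, and compound 2 `Cc1ccccc1C(=O)NCc1ccc(CNS(=O)(=O)c2ccccc2)cc1` gives "not active" (no number reported), without a number. Among the measured compounds shown here, the only single-place step measured, a number 9 percentage points higher from compound 1 to compound 3 (within the scatter), lies within the scatter. Compound 4 `O=C(NCc1ccc(CNS(=O)(=O)c2ccccc2)cc1)c1ccncc1` differs from compound 3 in one place: pyridin-4-yl in place of phenyl on a carbonyl carbon. The step that bears on this is that from compound 1 to compound 3 read in reverse, an aromatic nitrogen entering on the carbonyl carbon, and it was small. No step beyond the scatter is therefore expected in this assay , with a number 10 percentage points lower from compound 3 to compound 4 (within the scatter) as the expected change. Compound 4 is estimated at 52%, within 35% to 68%.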

Compound 4, a percentage reported as inhibition, in the whole organism at one dose (the size of the read-out at that dose, not a potency): 40%
Estimate against measurement, compound 4: 12 percentage points above, and the stated range covers the measured number.
By their numbers in this assay, from the lowest: compound 4; then compounds 1 and 3 (each within the scatter of the next).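

On the carbonyl carbon, a ring nitrogen is not neutral in every placement: this assay gives a number 22 percentage points lower from compound 3 to compound 4 (beyond the scatter), whereas the earlier pyridin-3-yl comparison gave only a number 9 percentage points higher from compound 1 to compound 3 (within the scatter). Moving from pyridin-3-yl to pyridin-4-yl also counts, with a number 13 percentage points lower from compound 1 to compound 4 (beyond the scatter), so the outcome depends on which pyridine isomer sits there and not merely on the presence of a ring nitrogen. No measured data explain this drop.

On these data alone, how pyridin-2-yl, or a saturated amine ring such as piperidin-4-yl, would behave on the same carbonyl carbon remains open.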